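This account rests on a few compounds, and the source may have more. Where it says the series, first, only, none or still open, it means among the compounds named here.

Compound 1, `Nc1cc(N)c2nc(-c3ccccc3)c(Oc3ccc(Cl)c(Cl)c3)nc2c1`, was tested in a functional assay on SF-268 cells (Homo sapiens) for inhibition, read by sulforhodamine B assay, with a stated time of 48 h; a higher number here means that more compound is tolerated, a lower number that less compound is tolerated. For compound 1 the result is recorded only as a limit of the assay, < 100000 nM, and not as a number. Compound 2, `CCOC(=O)[C@H](CCC(=O)O)NC(=O)c1ccc(Sc2nc3cc(N)cc(N)c3nc2-c2ccccc2)cc1`, was examined in the same way, and for compound 2 the outcome in this assay is likewise a limit of the assay, < 100000 nM. For the measured compounds named here, compound 3, `COc1cc(CNc2nc3cc(N)cc(N)c3nc2-c2ccccc2)cc(OC)c1OC`, is the one member of this set with a numerical reading, giving 49000 nM in this assay. Going by the values given here, compound 1 therefore stands where most of the set stands, at the limit of < 100000 nM in this assay, at which 2 of the 3 values shown sit, so no step between measured compounds can be drawn from these figures.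

The unmeasured compound 4, `Nc1cc(N)c2nc(-c3ccccc3)c(Sc3ccc(Cl)c(Cl)c3)nc2c1`, differs from compound 1 in a single place, ((3,4-dichlorophenyl)sulfanyl in place of 3,4-dichlorophenoxy on an aromatic carbon). Both groups carry the same count of heavy atoms, the same single aromatic ring and the same count of hydrogen-bond donors and acceptors, so the change is a small one. Because compound 1 sits at the limit of < 100000 nM in this assay, at which 2 of the 3 values shown sit, the step from compound 1 to compound 4 in this assay is expected to be no larger than the usual scatter, a step that the limit leaves unreadable from compound 1 to compound 4, in either direction. Compound 4 is accordingly estimated to give about 45000 nM in this assay, with a likely range from 12000 nM to 95000 nM.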

Compound 4, concentration lethal to 50% of the cells: < 100000 nM
Compound 4: a limit, no number (the forecaster's own chance of this, stated with the estimate: 45%); the middle value is on the limit's open side.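

In this assay compound 4 gives < 100000 nM, which is a limit of the assay and not a number. Compound 1 is also recorded only as a limit, so no step can be read between compound 1 and compound 4. The compounds shown leave open whether (3,4-dichlorophenyl)sulfanyl and 3,4-dichlorophenoxy on this aromatic carbon differ at all in this assay.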